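Vero cytotoxicity in the series: phenethyl to phenyl

The compounds below may be only part of what the source reports. "The series", "measured", "known", "first", "only" and "open" are said of these compounds alone.

Of the compounds shown here, three have been read in an ADME assay on Vero cells (Chlorocebus sabaeus) for cytotoxicity, read by resazurin assay, with a stated time of 3 days; a higher number here means a weaker inhibitor, a lower number a stronger inhibitor. Compound 1 `O=C(CCc1ccccc1)Nc1cc2nc(C3CCCCC3)[nH]c2cc1N1CCCC1` gives > 100 ug/mL in this assay, which is a limit of the assay and not a number. Compound 2 `CN(C)c1cc2[nH]c(C3CCCCC3)nc2cc1NC(=O)OCc1ccccc1` likewise returns > 100 ug/mL, again a limit. Compound 3 `C=Cc1cccc(C(=O)Nc2cc3nc(C4CCCCC4)[nH]c3cc2N(CC)CC)c1` returns > 100 ug/mL, also a limit. Going by the values given here, compound 1 thus stands where every value so far stands, namely at the limit of > 100 ug/mL in this assay, at which 3 of the 3 values shown sit, and no step between measured compounds exists from which the size of a change could be read.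

Compound 4 `O=C(Nc1cc2nc(C3CCCCC3)[nH]c2cc1N1CCCC1)c1ccccc1` is not yet measured. It differs from compound 1 by phenyl in place of phenethyl on a carbonyl carbon; cut one bond further out, the change reads phenethylcarbonyl to benzoyl. With every measured value sitting at the limit, no direction can be drawn from the series, and the expectation is no step beyond the usual scatter, with compound 4 most likely again reported only as a limit in this assay. Compound 4 is estimated at 150 ug/mL, with a range from 60 ug/mL to 400 ug/mL. The expected step is a step that the limit leaves unreadable from compound 1 to compound 4, that is, nothing beyond scatter.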

Compound 4, half-maximal inhibitory concentration: > 100 ug/mL
Compound 4 ended at the assay's limit; the forecaster's own chance of this, stated with the estimate: 80%; the middle value is on the limit's open side.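

Compound 1 and compound 4 both stand at a limit, not a number, in this assay, so no step between them can be read: the limit of > 100 ug/mL in this assay, at which 4 of the 4 values shown sit.

The compounds shown leave open whether any member of the series gives a measurable value in this assay, and how phenethyl and phenyl would then compare.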